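Chloro for Bromo: Estimating Compound 4 from Three Measurements

A few compounds are considered here, and "the series" means these few. Any claim that something is new, unique, unknown or untested is made for them only; others in the source may bear on it.

Measured compounds:
- compound 1, `O=C1C(=O)N(CCCCn2cc(COc3cc(=O)oc4ccccc34)nn2)c2ccc(Br)cc21`, in a functional assay on COLO 205 cells (Homo sapiens) for inhibition, read by sulforhodamine B assay, with a stated time of 48 h, tested at 50 uM (on this read-out lower numbers stand for less inhibition of growth and higher numbers for more inhibition of growth at the one concentration tested), compound 1 gives 56%
- compound 2, `O=C1C(=O)N(CCCCn2cc(COc3cc(=O)oc4ccccc34)nn2)c2ccc(Cl)cc21`, compound 2 gives 60%
- compound 3, `O=C1C(=O)N(CCCn2cc(COc3cc(=O)oc4ccccc34)nn2)c2ccc(Br)cc21`, compound 3 gives 61%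

Compound 1 and compound 2 differ in one place: chloro in place of bromo on an aromatic carbon. This change made a number 4 percentage points higher from compound 1 to compound 2 (within the scatter). Compound 3 carries a different core from compound 1; the difference between the two cores is not broken down here, and their values sit close together.

Compound 4, `O=C1C(=O)N(CCCn2cc(COc3cc(=O)oc4ccccc34)nn2)c2ccc(Cl)cc21`, is not yet measured. It differs from compound 3 by chloro in place of bromo on an aromatic carbon. The place of the change is the same as between compound 1 and compound 2, so it is the same change. From compound 3 to compound 4 the step is expected to be a number 3 percentage points higher from compound 3 to compound 4 (within the scatter), resting on the small step of a number 4 percentage points higher from compound 1 to compound 2 (within the scatter). Compound 4 is therefore estimated at 64%, with the range 52% to 76%.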

Compound 4, percent growth inhibition at one concentration: 67%
Compound 4: middle estimate off by 3 percentage points, on the low side, within the range that was stated.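

In this assay, chloro in place of bromo on an aromatic carbon gives a number 6 percentage points higher from compound 3 to compound 4 (within the scatter). Set beside the earlier step, the change carries from one core to the other without a detectable difference: the same change on two cores in this assay, a number 4 percentage points higher (within the scatter) from compound 1 to compound 2 and a number 6 percentage points higher (within the scatter) from compound 3 to compound 4, 2 percentage points apart, within the scatter of two such steps. Each step also lies within the scatter on its own, so neither shows that chloro truly gives more growth inhibition than bromo, and two cores cannot speak for the whole series.

The compounds shown carry only bromo or chloro at this place, which leaves open what fluoro, a methoxy group or an amine would do there. Also open, as far as these compounds go, is the effect of a longer chain on either halogen.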